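The source may hold more compounds than are shown below. What is called first, only, known or untested is meant among the compounds shown, and "the series" means these compounds.

In an ADME assay on H9c2 cells (Rattus norvegicus) for cytotoxicity, read by MTT assay, with a stated time of 48 h (a lower number here means a stronger inhibitor, a higher number a weaker inhibitor), three compounds have been measured so far:
Compound 1 `CC(C)(Oc1ccc(Cl)cc1)C(=O)NCCOC(=S)Nc1ccc(F)cc1` gives > 800000 nM as a limit.
Compound 2 `COc1ccc(NC(=S)OCCNC(=O)C(C)(C)Oc2ccc(Cl)cc2)cc1` gives 747000 nM as a number.
Compound 3 `O=C(NCCOC(=S)Nc1ccc(F)cc1)c1cccnc1` gives > 800000 nM as a limit.

Compound 3 stands at the limit of > 800000 nM in this assay, at which 2 of the 3 values shown sit, and so has no exact number in this assay to start from. Compound 4 `COc1ccc(NC(=S)OCCNC(=O)c2cccnc2)cc1` differs from compound 3 by methoxy in place of fluoro on an aromatic carbon, para to a large group (methoxy in place of fluoro on an aromatic carbon). The same exchange has been measured once, and it appears as an at least 1.0-fold lower number from compound 1 to compound 2 (0.02 log units; that floor lies within the scatter) in this series. Compound 1 is only a limit, so that step is a floor and not a measured size. For the measured compounds named here, compound 2 carries the methoxy group and gives 747000 nM as the only number available for such a compound. Resting on an at least 1.0-fold lower number from compound 1 to compound 2 (0.02 log units; that floor lies within the scatter) alone, no step beyond the scatter is expected in this assay, although a small move to a lower number would fit. The estimated change is an at least 1.0-fold lower number from compound 3 to compound 4 (0.02 log units; that floor lies within the scatter) and remains a rough expectation. For compound 4 the expected value is 760000 nM with an estimated range from 380000 nM to 1500000 nM and the assay may again report only a limit.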

Compound 4, half-maximal inhibitory concentration: 695000 nM
Compound 4: middle estimate off by 1.1-fold (0.04 log units), on the high side, within the range that was stated.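

In this assay, the exchange of fluoro for methoxy, para to a large group, can now be read on a second core, where it gives an at least 1.1-fold lower number from compound 3 to compound 4 (0.06 log units; that floor lies within the scatter). Like compound 2, compound 4 carries methoxy and returns an exact number, while compound 1 and compound 3, which carry fluoro, both stop at a limit, so across these four compounds the split between a number and a limit follows this exchange, and none goes against it: the limit of > 800000 nM in this assay, at which 2 of the 4 values shown sit. The two cores can be set side by side only as floors, and neither floor passes the usual scatter: the same change on two cores in this assay, an at least 1.0-fold lower number (0.02 log units; that floor lies within the scatter) from compound 1 to compound 2 and an at least 1.1-fold lower number (0.06 log units; that floor lies within the scatter) from compound 3 to compound 4; the limit leaves it open whether they differ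

As far as these compounds go, the true size of the step remains open on both cores, as does the question of whether methoxy in place of fluoro has any real effect in this assay at all. Also open, from the compounds shown here alone, is how a different group in the same place, such as an amine, a carboxylic acid or a longer alkoxy chain, would read in this assay, and whether any such group would give a number clearly lower than those of the two methoxy compounds.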